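Benzyl on the piperidine ring of compound 1

The source may report more compounds than this note shows. Statements on the series, on what has been measured and on what is new or still open speak of the compounds shown alone.

Compound 1 `Cc1c(C(C)C)c(=O)on1C(=O)N1CCCCC1` is the strongest of the three measured compounds: in an assay (strain Wistar) for inhibition of Hormone-sensitive lipase (Rattus norvegicus), read by spectrophotometry (on this read-out higher numbers stand for weaker inhibition and lower numbers for stronger inhibition), compound 1 gives 2 nM, the lowest of the three numbers. Compound 2 `Cc1c(C(C)C)c(=O)on1C(=O)N1CCOCC1` gives 52 nM, and compound 3 `Cc1c(C(C)C)c(=O)on1C(=O)N1CCCC(CO)C1` gives 180 nM. Both measured steps away from compound 1 weaken inhibition: a 26-fold higher number from compound 1 to compound 2 (1.41 log units; beyond the scatter) and a 90-fold higher number from compound 1 to compound 3 (1.95 log units; beyond the scatter).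

Compound 4 `Cc1c(C(C)C)c(=O)on1C(=O)N1CCC(Cc2ccccc2)CC1` differs from compound 1 by benzyl in place of hydrogen on a saturated ring carbon. Going by the values given here, no measured pair shows exactly this change. The closest guide is the step to compound 3, where a hydroxymethyl group entering a saturated ring carbon of the same ring cost a large amount, and the step to compound 2 shows that even a small alteration of that ring is felt. A benzyl group is a larger addition than either, so a weakening beyond the scatter is the likelier outcome, though its size is uncertain. He therefore expects compound 4 to give 20 nM in this assay, within a range from 3 nM to 200 nM, which means an expected step of a 10-fold higher number from compound 1 to compound 4 (1.00 log units; beyond the scatter).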

Compound 4, half-maximal inhibitory concentration: 102 nM
Compound 4: the middle estimate sits 5.1-fold (0.71 log units) below what was measured; the range from low to high includes it.
By their numbers in this assay, from the lowest: compound 1; then compounds 2, 4 and 3 (each within the scatter of the next, the first and the last beyond it).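

The a 51-fold higher number from compound 1 to compound 4 (1.71 log units; beyond the scatter) shows that a group of carbon only, with 0 hydrogen-bond donors and 0 hydrogen-bond acceptors, also weakens inhibition on a saturated ring carbon three ring bonds from the ring nitrogen. The earlier changes to this ring, morpholin-4-yl and hydroxymethyl, both brought in oxygen, so oxygen is not needed for a large loss, and none of the three changes to the ring of compound 1 goes against this. Nothing measured here explains the loss.

The compounds shown leave open whether a methyl group, much smaller than benzyl, would be tolerated on this same ring carbon. They also leave open how an amine or a carboxylic acid placed there would compare with benzyl.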